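Extending the sulfur-bound chain: compound 1 to compound 3

The source may hold more compounds than are shown below. What is called first, only, known or untested is meant among the compounds shown, and "the series" means these compounds.

Compound 1 `CCCSc1nc2nc(C)cc(N3CC[C@@H](C)[C@@H](N(C)c4ncnc5[nH]ccc45)C3)n2n1`: 20900 nM
Compound 2 `Cc1cc(N2CC[C@@H](C)[C@@H](N(C)c3ncnc4[nH]ccc34)C2)n2nc(SCC3CCCCC3)nc2n1`: 11500 nM

In a functional assay on HGC-27 cells (Homo sapiens) for inhibition, read by MTT assay, with a stated time of 72 h (a higher number here means a weaker inhibitor, a lower number a stronger inhibitor), compound 1 gives 20900 nM, the highest of the two numbers measured. Compound 2 gives 11500 nM. Compound 3 `Cc1cc(N2CC[C@@H](C)[C@@H](N(C)c3ncnc4[nH]ccc34)C2)n2nc(SCc3ccc(C(F)(F)F)cc3)nc2n1` differs from compound 1 in one place: 4-(trifluoromethyl)phenyl in place of ethyl on a saturated chain carbon bound to a sulfur. Within the data shown here, the only measured step touching the same carbon is a 1.8-fold lower number from compound 1 to compound 2 (0.26 log units; within the scatter), and it stayed within the scatter. Enlarging the group on that carbon has therefore shown no clear effect, so no step beyond the scatter is expected. Compound 3 is estimated at 14000 nM, with a range from 5000 nM to 40000 nM. This expectation means a 1.5-fold lower number from compound 1 to compound 3 (0.17 log units; within the scatter).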

Compound 3, half-maximal inhibitory concentration: 9540 nM
Estimate against measurement, compound 3: 1.5-fold (0.17 log units) above; the measured number falls inside the stated range.
By their numbers in this assay, from the lowest: compounds 3, 2 and 1 (each within the scatter of the next, the first and the last beyond it).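

In this assay, 4-(trifluoromethyl)phenyl on the saturated chain carbon bound to a sulfur gives a 2.2-fold lower number from compound 1 to compound 3 (0.34 log units; beyond the scatter), so a change at this carbon now lies beyond the scatter, though only modestly. Aromatic and saturated rings are not told apart here, with a 1.2-fold lower number from compound 2 to compound 3 (0.08 log units; within the scatter). No measurement at hand explains the shift. Still open, on these data alone, is whether plain phenyl would do the same, which would show if the trifluoromethyl matters, and how an amine or a carboxylic acid at this carbon would fare.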